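This account rests on a few compounds, and the source may have more. Where it says the series, first, only, none or still open, it means among the compounds named here.

Compound 1, whose structure is `COc1ccc(-c2cc(Cl)cn3c([N+](=O)[O-])c(CS(=O)(=O)c4ccccc4)nc23)cc1`, was tested in an ADME assay on HepG2 cells (Homo sapiens) for cytotoxicity, read by MTT assay, with a stated time of 72 h; a lower number here means that less compound is tolerated, a higher number that more compound is tolerated. In this assay compound 1 gives only a limit, > 3900 nM, and no number. Compound 2, `O=[N+]([O-])c1c(CS(=O)(=O)c2ccccc2)nc2c(-c3cccc(C(F)(F)F)c3)cc(Cl)cn12`, carries a 3-(trifluoromethyl)phenyl in place of the 4-methoxyphenyl on an aromatic carbon. In this assay compound 2 likewise gives only a limit, > 12500 nM, so the step that the two limits leave unreadable from compound 1 to compound 2 cannot be read in size or direction. Among the measured compounds shown here, the two limits the limit of > 12500 nM in this assay, at which 1 of the 2 values shown sits, and the limit of > 3900 nM in this assay, at which 1 of the 2 values shown sits, together show only that neither compound reached a half-maximal cytotoxic concentration within the range tested. Compound 3, `O=[N+]([O-])c1c(CS(=O)(=O)c2ccccc2)nc2c(-c3ccncc3)cc(Cl)cn12`, differs from compound 1 as follows: pyridin-4-yl in place of 4-methoxyphenyl on an aromatic carbon. For the measured compounds named here, no measured step bears on this change, and the one step recorded for the shared core is unreadable, so no size or direction of a step in this assay can be inferred from the evidence at hand. Compound 3 is therefore expected to remain untoxic within the tested range, with a step that the limit leaves unreadable from compound 1 to compound 3 judged to lie within the scatter, and its estimated half-maximal cytotoxic concentration is 8000 nM, between 3000 nM and 25000 nM, most likely reported as a limit.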

Compound 3, half-maximal cytotoxic concentration: > 50000 nM
Compound 3 gave a limit, no number; the forecaster's own chance of this, stated with the estimate: 75%; middle value at least 6.2-fold (0.79 log units) from the limit.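

In this assay compound 3 gives only a limit, > 50000 nM, and no number. Among the compounds shown here, since compound 1 and compound 2 also stand as limits, no step to compound 3 from either can be read. The compounds shown leave open at what concentration any of the three reaches its half-maximal cytotoxic concentration, and whether changing the aromatic group alters it.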